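The source may report more compounds than this note shows. Statements on the series, on what has been measured and on what is new or still open speak of the compounds shown alone.

In an ADME assay on SH-SY5Y cells (Homo sapiens) for cytotoxicity, read by MTT assay, with a stated time of 72 h (on this read-out lower numbers stand for higher toxicity in this test and higher numbers for lower toxicity in this test), compound 1 `c1ccc(-c2ccc3nc(-c4ccco4)cn3c2)cc1` gives 420 nM, and compound 3 `Nc1cc(-c2ccco2)cn2cc(-c3ccco3)nc12` gives 2270 nM, the higher of these two numbers. Compound 2 `Nc1cccn2cc(-c3ccco3)nc12` gives only a limit of the assay, > 100000 nM. For the measured compounds named here, the one measured step, an at least 44-fold lower number from compound 2 to compound 3 (1.64 log units; beyond the scatter), has furan-2-yl in place of hydrogen on an aromatic carbon, and it is large. Compound 4 `Nc1cc(-c2ccccc2)cn2cc(-c3ccco3)nc12` changes that same group: phenyl in place of furan-2-yl on an aromatic carbon. Going by the values given here, no measured step exchanges these two groups, so the large step shows only that adding furan-2-yl there coincides with a much lower number, not what a swap for phenyl would do. Compound 1, which also carries a phenyl, gives 420 nM, and this tilts the expectation slightly toward lower numbers in this assay. The expected change, a 1.5-fold lower number from compound 3 to compound 4 (0.18 log units; within the scatter), is small and is not expected to go beyond the scatter. Compound 4 is therefore estimated at 1500 nM, within an expected range of 450 nM to 5000 nM.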

Compound 4, half-maximal cytotoxic concentration: 500 nM
Estimate against measurement, compound 4: 3.0-fold (0.48 log units) above, within the range that was stated.
By their numbers in this assay, from the lowest: compounds 1 and 4 (each within the scatter of the next); then compound 3. At a limit, above all of these: compound 2.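

The position two atoms from the ring nitrogen responds not only to whether an aromatic ring is present but to which one it carries: in this assay, phenyl in place of furan-2-yl gives a 4.5-fold lower number from compound 3 to compound 4 (0.66 log units; beyond the scatter). Phenyl in place of hydrogen there gives an at least 200-fold lower number from compound 2 to compound 4 (2.30 log units; beyond the scatter), a step that starts from a limit of the assay: the limit of > 100000 nM in this assay, at which 1 of the 4 values shown sits. With phenyl on the core, amino in place of hydrogen gives a 1.2-fold higher number from compound 1 to compound 4 (0.08 log units; within the scatter), so in this pair the amino group does not separate the two numbers beyond the scatter.

Open, going by these compounds, is whether a pyridine ring or a small chain such as methyl at this position would follow phenyl or furan-2-yl. Also open, on these data alone, is what replacing the furan-2-yl shared by all four compounds with a thiophene ring would do.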